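Cytotoxicity series: acetylthiophene replaces pyridine on the biaryl

The source may hold more compounds than are shown below. What is called first, only, known or untested is meant among the compounds shown, and "the series" means these compounds.

Compound 3 `CCOC(=O)CCCCCOc1cccc(CN(C(=O)c2ccc(-c3ccncc3)cc2)C(C)C)c1` sits at a limit in an ADME assay on BJ cells (Homo sapiens) for cytotoxicity, read by CellTiter-Glo and resazurin assay, with a stated time of 72 h; a lower number here means that less compound is needed, a higher number that more compound is needed for the effect: compound 3 gives > 26000 nM, a limit of the assay rather than a number. Compound 2 `CC(C)N(Cc1cccc(OCCCCCC(=O)O)c1)C(=O)c1ccc(-c2ccncc2)cc1` gives in this assay > 26000 nM, again a limit. Compound 1 `CC(C)N(Cc1cccc(OCCCCCC(=O)O)c1)C(=O)c1ccc(-c2cccc(N(C)C)c2)cc1` gives in this assay > 26000 nM, also a limit. All three values sit at the limit of > 26000 nM in this assay, at which 3 of the 3 values shown sit, so the step that the two limits leave unreadable from compound 1 to compound 2 and the step that the two limits leave unreadable from compound 2 to compound 3 are both unreadable, and compound 3 stands where the others stand, at the limit. Compound 4 `CCOC(=O)CCCCCOc1cccc(CN(C(=O)c2ccc(-c3ccc(C(C)=O)s3)cc2)C(C)C)c1` differs from compound 3 by 5-acetylthiophen-2-yl in place of pyridin-4-yl on an aromatic carbon. Among the measured compounds shown here, no measured step bears on this change, and the two steps were both hidden by the limit, so no size or direction can be drawn from them. Nothing in the series shows a change moving the readout into the measurable range. The expected step of a number no higher from compound 3 to compound 4 (the limit leaves the size open) is therefore nil within the scatter. Compound 4 is estimated at 26000 nM, with a range from 15000 nM to 60000 nM, most likely reported only as a limit again.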

Compound 4, half-maximal effective concentration: > 26000 nM
Compound 4: a limit, no number; the forecaster's own chance of this, stated with the estimate: 80%; the middle value lies on the limit itself.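

In this assay compound 3 and compound 4 both sit at a limit, and no step between them can be read: the limit of > 26000 nM in this assay, at which 4 of the 4 values shown sit.

The compounds shown leave open whether any change to the shared core brings this read-out into the measurable range.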